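Adding one more double bond at the assay limit

The source may report more compounds than this note shows. Statements on the series, on what has been measured and on what is new or still open speak of the compounds shown alone.

- Compound 1 `CCCC/C=C\CCCCCCCCCc1cc(=O)c2c(O)c(C)c(OCOC)cc2o1`: > 67200 nM (a limit)
- Compound 2 `CCCCCCCCCCCCCCCc1cc(=O)c2c(O)c(C)c(OCOC)cc2o1`: > 67200 nM (a limit)
- Compound 3 `CCCCC/C=C\C/C=C\CCCCCCCc1cc(=O)c2c(O)c(C)c(OCOC)cc2o1`: > 67200 nM (a limit)

These values come from a functional assay on MCF7 cells (Homo sapiens) for antiproliferative activity, read by MTT assay; on this read-out lower numbers stand for stronger inhibition and higher numbers for weaker inhibition. Compound 3 has no number, only a limit. It shares this position with the other two compounds: the limit of > 67200 nM in this assay, at which 3 of the 3 values shown sit.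

Compound 4 `CC/C=C\C/C=C\C/C=C\CCCCCCCc1cc(=O)c2c(O)c(C)c(OCOC)cc2o1` changes the chain of compound 3: but-1-en-1-yl in place of butyl on a saturated chain carbon bound to a double-bonded chain carbon.

The nearest evidence is a step that the two limits leave unreadable from compound 1 to compound 2, a step that the two limits leave unreadable from compound 1 to compound 3 and a step that the two limits leave unreadable from compound 2 to compound 3. None of these chain changes has a readable size, so no step beyond the scatter, in either direction, is expected in this assay. The expected step is a step that the limit leaves unreadable from compound 3 to compound 4. The estimate for compound 4 is 80000 nM, with a range of 40000 nM to 160000 nM, and a reported limit is the likeliest outcome.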

Compound 4, half-maximal inhibitory concentration: 17500 nM
For compound 4 the middle estimate is 4.6-fold (0.66 log units) above the measured one; the measured number lies below the stated range.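

Going by these compounds alone, replacing butyl with but-1-en-1-yl, on a saturated chain carbon bound to a double-bonded chain carbon, gives the first readable step in this assay, an at least 3.8-fold lower number from compound 3 to compound 4 (0.58 log units; beyond the scatter). The other two chains give the same reading, an at least 3.8-fold lower number from compound 2 to compound 4 (0.58 log units; beyond the scatter) and an at least 3.8-fold lower number from compound 1 to compound 4 (0.58 log units; beyond the scatter). Compound 1, compound 2 and compound 3 remain at a limit: the limit of > 67200 nM in this assay, at which 3 of the 4 values shown sit.

On these data alone, each step is only a minimum, so its true size stays open, and the steps among compound 1, compound 2 and compound 3 cannot be read. As far as these compounds go, whether a shorter chain or a carboxylic acid in place of this chain would change the number also remains open.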